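A few compounds are considered here, and "the series" means these few. Any claim that something is new, unique, unknown or untested is made for them only; others in the source may bear on it.

Compound 1 `CCOCCOC(=O)C(=O)Nc1nc(-c2cc(Cl)no2)cs1`: > 30 mg/kg
Compound 2 `CCOCCOC(=O)C(=O)Nc1nc(-c2cc(Br)no2)cs1`: > 30 mg/kg
Compound 3 `CCOC(=O)C(=O)Nc1nc(-c2cc(Br)no2)cs1`: > 100 mg/kg

In a functional assay on the whole organism with Rattus norvegicus as the target (on this read-out lower numbers stand for an effect already at smaller amounts and higher numbers for an effect only at larger amounts of compound), compound 2 stands at > 30 mg/kg, which is a limit and not a number. Compound 1 shares this limit, (the limit of > 30 mg/kg in this assay, at which 2 of the 3 values shown sit). Compound 3 sits at another limit, (the limit of > 100 mg/kg in this assay, at which 1 of the 3 values shown sits).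

Compound 4 `CCOCCOC(=O)C(=O)Nc1nc(-c2cc(Br)no2)c(CC)s1` differs from compound 2 by ethyl in place of hydrogen on an aromatic carbon. Two measured steps lie nearby, a step that the two limits leave unreadable from compound 1 to compound 2 and a step that the two limits leave unreadable from compound 2 to compound 3. Both change other places, and neither has a readable size, so they give no size or direction to carry over. The expected step that the limit leaves unreadable from compound 2 to compound 4 is therefore only a broad estimate. In this assay compound 4 is expected at 35 mg/kg, with an estimated range from 12 mg/kg to 100 mg/kg.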

Compound 4, dose for half-maximal effect: 9 mg/kg
Estimate against measurement, compound 4: 3.9-fold (0.59 log units) above; the measured number lies below the stated range.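

Ethyl in place of hydrogen on the aromatic carbon next to the ring sulfur gives an at least 3.3-fold lower number from compound 2 to compound 4 (0.52 log units; beyond the scatter) in this assay. The earlier steps cannot be read, so this position is the first place shown where a single change has a readable effect, and its direction is toward smaller doses. No information given here accounts for this step. Going by these compounds, whether methyl or a longer chain such as propyl at this position would give a lower or a higher number remains open. So does whether ethyl has the same effect with chloro in place of bromo.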